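The source may report more compounds than this note shows. Statements on the series, on what has been measured and on what is new or still open speak of the compounds shown alone.

Among the measured compounds shown here, compound 2 `Cc1ccc(S(=O)(=O)/N=C(/CCNC2=CC(=O)c3ccccc3C2=O)Nc2ccc(Cl)cc2Cl)cc1` gives 32900 nM in a functional assay on A549 cells (Homo sapiens) for cytotoxicity, read by MTT assay, with a stated time of 48 h (on this read-out lower numbers stand for stronger inhibition and higher numbers for weaker inhibition), the highest of the two numbers measured so far. Its nearest neighbour, compound 1 `COc1ccc(N/C(CCNC2=CC(=O)c3ccccc3C2=O)=N\S(=O)(=O)c2ccc(C)cc2)cc1OC`, gives 20500 nM in this assay. The step of a 1.6-fold higher number from compound 1 to compound 2 (0.21 log units; within the scatter) stays within the scatter. Compound 3 `Cc1ccc(S(=O)(=O)/N=C(\N)CCNC2=CC(=O)c3ccccc3C2=O)cc1` differs from compound 2 by hydrogen in place of 2,4-dichlorophenyl on an amine nitrogen. For the measured compounds named here, only the step from compound 1 to compound 2 bears on this, and exchanging one aryl group for another moved the number little. Going by the values given here, removing the aryl group entirely has no measured counterpart, so the expected step of a 1.4-fold higher number from compound 2 to compound 3 (0.14 log units; within the scatter) is modest and uncertain, leaning toward a higher number. Compound 3 is estimated at 45000 nM, within 12000 nM to 150000 nM.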

Compound 3, half-maximal inhibitory concentration: 26600 nM
Compound 3: the middle estimate sits 1.7-fold (0.23 log units) above what was measured; the range from low to high includes it.
By their numbers in this assay, from the lowest: compounds 1, 3 and 2 (each within the scatter of the next).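

With hydrogen in place of 2,4-dichlorophenyl the result is a 1.2-fold lower number from compound 2 to compound 3 (0.09 log units; within the scatter) and with hydrogen in place of 3,4-dimethoxyphenyl it is a 1.3-fold higher number from compound 1 to compound 3 (0.11 log units; within the scatter) so removing the aryl group altogether, not only exchanging it, stays within the scatter. On this amine nitrogen, neither aryl group separates its compound from the plain amino compound 3. Nothing available accounts for this result. As far as these compounds go, whether a methyl or benzyl group on this nitrogen, or a longer chain in the shared core, would move the number beyond the scatter remains open.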